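This account rests on a few compounds, and the source may have more. Where it says the series, first, only, none or still open, it means among the compounds named here.

Compound 1 `Nc1ccccc1NC(=O)c1ccc(CSC(=S)N2CCc3ccccc32)cc1`: 3040 nM
Compound 2 `Nc1ccccc1NC(=O)c1ccc(CSC(=S)N2CCc3cc(Cl)ccc32)cc1`: 1880 nM
Compound 3 `COC(=O)c1ccc2c(c1)CCN2C(=S)SCc1ccc(C(=O)Nc2ccccc2N)cc1`: not yet measured

In a functional assay on SMMC-7721 cells (Homo sapiens) for antiproliferative activity, read by CCK-8 assay, with a stated time of 72 h (on this read-out higher numbers stand for weaker inhibition and lower numbers for stronger inhibition), compound 2 gives 1880 nM, which lies within the scatter of compound 1. Compound 3 differs from compound 2 as follows: methoxycarbonyl in place of chloro on an aromatic carbon. For the measured compounds named here, the only measured step that bears on this change is a 1.6-fold lower number from compound 1 to compound 2 (0.21 log units; within the scatter), and no measured compound carries methoxycarbonyl. On that evidence, no step beyond the scatter is expected in this assay. The estimate corresponds to a 1.3-fold higher number from compound 2 to compound 3 (0.12 log units; within the scatter). The expected value for compound 3 is 2500 nM, with an estimated range of 1000 nM to 6000 nM.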

Compound 3, half-maximal inhibitory concentration: > 32000 nM
Compound 3: no number, only a limit; the forecaster's own chance of this, stated with the estimate: 2%; middle value at least 12-fold (1.10 log units) away from the limit.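

In this assay compound 3 has only a limit of the assay, not a number: the limit of > 32000 nM in this assay, at which 1 of the 3 values shown sits.

This aromatic carbon is therefore not indifferent to what it carries. Chloro in place of hydrogen stayed within the scatter, whereas methoxycarbonyl in place of chloro gives an at least 17-fold higher number from compound 2 to compound 3 (1.23 log units; beyond the scatter), and methoxycarbonyl in place of hydrogen gives an at least 10-fold higher number from compound 1 to compound 3 (1.02 log units; beyond the scatter). Both steps rest on the limit, so their full size cannot be read.

Going by these compounds, it remains open whether a carboxylic acid, a primary amide or a methoxy group on the same carbon would track chloro or methoxycarbonyl.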